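The compounds below may be only part of what the source reports. "The series", "measured", "known", "first", "only" and "open" are said of these compounds alone.

Measured compounds:
- compound 1, `CC/C(=C(/c1ccc(/C=C/C(=O)O)cc1)c1cc2ccccc2[nH]1)c1ccccc1C`: 33 nM
- compound 2, `CC/C(=C(/c1ccc(/C=C/C(=O)O)cc1)c1cc2ccccc2[nH]1)c1cccc(C)c1`: 140 nM
- compound 3, `CC/C(=C(/c1ccc(/C=C/C(=O)O)cc1)c1cc2ccccc2[nH]1)c1ccc(C(F)(F)F)cc1`: 139 nM

In a functional assay on MCF7 cells (Homo sapiens) for inhibition (a higher number here means a weaker inhibitor, a lower number a stronger inhibitor), compound 1 gives the lowest number of the three, with compound 2 and compound 3 both beyond the scatter above it. The two measured steps from compound 1 each replace its 2-methylphenyl group: a 4.2-fold higher number from compound 1 to compound 2 (0.63 log units; beyond the scatter) and a 4.2-fold higher number from compound 1 to compound 3 (0.62 log units; beyond the scatter), while between compound 2 and compound 3 the change is a 1.0-fold lower number from compound 2 to compound 3 (0.00 log units; within the scatter).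

Compound 4, `CC/C(=C(/c1ccc(/C=C/C(=O)O)cc1)c1cc2ccccc2[nH]1)c1cccc(Cl)c1Cl`, differs from compound 1 by 2,3-dichlorophenyl in place of 2-methylphenyl on a double-bonded chain carbon bound to a double-bonded chain carbon and a saturated chain carbon. Among the measured compounds shown here, no measured pair carries a chlorine-bearing ring or a ring with two substituents, so the step can only be weighed against the two steps away from compound 1, both of which loosened inhibition by a modest amount. Compound 4 is therefore expected to land close to compound 1 or somewhat weaker, a 1.8-fold higher number from compound 1 to compound 4 (0.26 log units; within the scatter), and the estimate for compound 4 in this assay is 60 nM, within 20 nM to 250 nM.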

Compound 4, half-maximal inhibitory concentration: 898 nM
Beside the measured number, compound 4's estimate is 15-fold (1.18 log units) below it; measured number above the stated range.
By their numbers in this assay, from the lowest: compound 1; then compounds 3 and 2 (each within the scatter of the next); then compound 4.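

In this assay, among the compounds shown here, the group on this double-bonded chain carbon turns out to carry far more weight than the earlier replacements showed, since a 27-fold higher number from compound 1 to compound 4 (1.43 log units; beyond the scatter) is the only step here graded large. The 2,3-dichlorophenyl group also falls away from the other two replacements, with a 6.5-fold higher number from compound 3 to compound 4 (0.81 log units; beyond the scatter) and a 6.4-fold higher number from compound 2 to compound 4 (0.81 log units; beyond the scatter) as well, so the level shared by the 3-methylphenyl and 4-(trifluoromethyl)phenyl groups is not a lower limit on what a change at this carbon can cost. Nothing available explains why this change costs so much.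

The compounds shown leave open whether one chlorine alone, as in a 2-chlorophenyl or a 3-chlorophenyl group, would bring the same loss or whether it takes both chlorines together. They also leave open how a 2-ethylphenyl or a 2-methoxyphenyl group would compare with the 2-methylphenyl group of compound 1 at this carbon.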